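A few compounds are considered here, and "the series" means these few. Any claim that something is new, unique, unknown or untested is made for them only; others in the source may bear on it.

Working notes on the sulfone series.

Compound 3 `O=S(=O)(c1ccc(F)cc1)c1cnc2cc(F)ccc2c1-c1ccc(Cl)cc1` carries 4-fluorophenyl on the sulfonyl sulfur. Among the measured compounds shown here, in an ADME assay on microsomes from liver (Homo sapiens) for metabolic stability, tested at 2.5 uM (a lower number here means slower removal, a higher number faster removal of the compound), compound 3 gives 1.23 mL/min, the second highest of the three numbers so far. Compound 1 `O=S(=O)(c1cc(Cl)cc(Cl)c1)c1cnc2cc(F)ccc2c1-c1ccc(Cl)cc1` gives 0.13 mL/min in this assay; compound 2 `Cc1ccc(S(=O)(=O)c2cnc3cc(F)ccc3c2-c2cccc(Cl)c2)cc1C` gives 4.01 mL/min, the highest of the three.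

The step to compound 4 `Cc1ccc(S(=O)(=O)c2cnc3cc(F)ccc3c2-c2ccc(Cl)cc2)cc1C` is 3,4-dimethylphenyl in place of 4-fluorophenyl on a sulfonyl sulfur. For the measured compounds named here, no measured step alters the same group in the same way, so the bearing is indirect. Going by the values given here, the one step at the sulfonyl sulfur, a 9.5-fold higher number from compound 1 to compound 3 (0.98 log units; beyond the scatter), shows that exchanging the aryl group there moves this assay well beyond the scatter. Compound 2 also carries 3,4-dimethylphenyl on the sulfonyl sulfur and gives 4.01 mL/min, though it differs from compound 4 elsewhere, so it is only a pointer.

For compound 4 a higher number than compound 3 is expected in this assay, with the step of a 2.8-fold higher number from compound 3 to compound 4 (0.45 log units; beyond the scatter). Compound 4 is estimated at 3.5 mL/min, in a range from 1.5 mL/min to 8 mL/min.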

Compound 4, intrinsic clearance in a liver preparation (reported as CLH), per the amount of preparation that the assay uses: 7.88 mL/min
Compound 4: middle estimate off by 2.3-fold (0.35 log units), on the low side, within the range that was stated.
By their numbers in this assay, from the lowest: compound 1; then compound 3; then compounds 2 and 4 (each within the scatter of the next).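

With the 4-chlorophenyl group and the shared core held constant, the aryl group on the sulfonyl sulfur now forms a series of three in this assay: a 6.4-fold higher number from compound 3 to compound 4 (0.81 log units; beyond the scatter) and a 61-fold higher number from compound 1 to compound 4 (1.78 log units; beyond the scatter) place 3,4-dimethylphenyl at the high end, with 4-fluorophenyl in the middle and 3,5-dichlorophenyl lowest. The exchange of 3-chlorophenyl for 4-chlorophenyl on an aromatic carbon gives a 2.0-fold higher number from compound 2 to compound 4 (0.29 log units; within the scatter), so among these compounds the clear differences come from the group on the sulfonyl sulfur. Nothing at hand explains why these groups differ.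

The compounds shown leave open whether a single methyl group, as in 4-methylphenyl, would give a number like that of 3,4-dimethylphenyl. They also leave open how an amine or a carboxylic acid on that aryl ring would behave.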